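Compound 3 to compound 4: hydrogen replaces chloro

The source may hold more compounds than are shown below. What is called first, only, known or untested is meant among the compounds shown, and "the series" means these compounds.

In a functional assay on HT-29 cells (Homo sapiens) for inhibition, read by sulforhodamine B assay, with a stated time of 48 h (on this read-out higher numbers stand for weaker inhibition of growth and lower numbers for stronger inhibition of growth), compound 3 `CC(C)(C)NCc1c(C(=O)O)nn(-c2ccc(Cl)cc2)c1-c1ccc(Cl)cc1` gives only a limit, > 599000 nM. Compound 2 `CC(C)(C)NCc1c(C(=O)O)nn(-c2ccc(Cl)cc2)c1-c1ccc(F)cc1` likewise gives only a limit, > 623000 nM. Compound 1 `CCOC(=O)c1nn(-c2ccc(Cl)cc2)c(-c2ccccc2)c1CNC(C)(C)C` has several entries, 336000 nM; > 559000 nM (2 entries). Compound 3 therefore has no exact position on the numbers shown.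

Compound 4 `CC(C)(C)NCc1c(C(=O)O)nn(-c2ccc(Cl)cc2)c1-c1ccccc1` departs from compound 3 at one place, hydrogen in place of chloro on an aromatic carbon, so that 4-chlorophenyl becomes phenyl. For the measured compounds named here, the one measured step bearing on this, a step that the two limits leave unreadable from compound 2 to compound 3, puts chloro in place of fluoro on an aromatic carbon. It offers no size to carry over, so no step beyond the scatter is expected in this assay, and no direction can be favoured. The expected result is a step that the limit leaves unreadable from compound 3 to compound 4. A limit is the most likely report for the new compound. Compound 4 is estimated at 620000 nM, with an expected range of 300000 nM to 1000000 nM.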

Compound 4, concentration for 50% growth inhibition: > 652000 nM
Compound 4 ended at the assay's limit (the forecaster's own chance of this, stated with the estimate: 85%); at least 1.0-fold (0.02 log units) between middle value and limit.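

For the compounds shown here, compound 2, compound 3 and compound 4 each give only a limit in this assay, so no step among them can be read. Going by these compounds, whether hydrogen, fluoro or chloro on that aromatic carbon makes any difference to inhibition of growth remains open.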